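The source may hold more compounds than are shown below. What is called first, only, known or untested is meant among the compounds shown, and "the series" means these compounds.

Measured compounds in a functional assay on HL-60 cells (Homo sapiens) for cytotoxicity, read by MTT assay, with a stated time of 48 h; a higher number here means a weaker inhibitor, a lower number a stronger inhibitor:
compound 1 `COc1ccc2[nH]c(-c3cccc(F)c3)cc(=O)c2c1O` gives 30 nM
compound 2 `COc1ccc2[nH]c(-c3ccc(F)cc3)cc(=O)c2c1O` gives 1800 nM
compound 3 `COc1cc2c(=O)cc(-c3cccc(F)c3)[nH]c2cc1O` gives 900 nM

Compound 1 and compound 2 share one core and differ by 4-fluorophenyl in place of 3-fluorophenyl on an aromatic carbon; in this assay the step is a 60-fold higher number from compound 1 to compound 2 (1.78 log units; beyond the scatter), so the move to the 4-fluorophenyl costs a great deal on that core. Compound 3 carries the 3-fluorophenyl on a second core; the difference between the two cores is not broken down here. Its value is close to that of compound 2 and far weaker than that of compound 1.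

Compound 4 `COc1cc2c(=O)cc(-c3ccc(F)cc3)[nH]c2cc1O` is not yet measured. It differs from compound 3 by 4-fluorophenyl in place of 3-fluorophenyl on an aromatic carbon, the same change as that from compound 1 to compound 2, on an identical place. As far as these compounds go, the step from compound 3 to compound 4 is expected to be in the same direction, estimated as a 22-fold higher number from compound 3 to compound 4 (1.35 log units; beyond the scatter), resting on the step from compound 1 to compound 2 of a 60-fold higher number from compound 1 to compound 2 (1.78 log units; beyond the scatter); whether the second core carries the change with the same size is unknown, so the range is kept wide. Compound 4 is expected to give about 20000 nM, estimated between 3000 nM and 100000 nM.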

Compound 4, half-maximal inhibitory concentration: 38200 nM
Estimate against measurement, compound 4: 1.9-fold (0.28 log units) below; the measured number falls inside the stated range.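

In this assay, 4-fluorophenyl in place of 3-fluorophenyl gives a 42-fold higher number from compound 3 to compound 4 (1.63 log units; beyond the scatter). Going by these compounds alone, the same change has now been read on two cores, and the two steps agree in direction and in size: the same change on two cores in this assay, a 60-fold higher number (1.78 log units; beyond the scatter) from compound 1 to compound 2 and a 42-fold higher number (1.63 log units; beyond the scatter) from compound 3 to compound 4, 1.4-fold (0.15 log units) apart, within the scatter of two such steps Within this assay, the cost of the 4-fluorophenyl therefore carries from the core of compound 1 to the core of compound 3, but this rests on only two cores and one pair of fluorophenyl groups, and it shows neither the reason for the cost nor whether it would hold on a further core or in another assay.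

Still open, as far as these compounds go, is how either fluorophenyl group compares with an unsubstituted phenyl, a chlorophenyl or an aminophenyl on these cores. Also open, from the compounds shown here alone, are what separates the two cores themselves and what follows when the hydroxyl or methoxy group gives way to an amine or a longer alkoxy chain.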